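Swapping the benzyl substituent on an adenosine receptor binder

The source may hold more compounds than are shown below. What is called first, only, known or untested is meant among the compounds shown, and "the series" means these compounds.

Measured so far:
compound 1, `CCCn1c(=O)c2nc(-c3cnn(Cc4ccccc4C(F)(F)F)c3)[nH]c2n(CCC)c1=O`, 44 nM;
compound 2, `CCCn1c(=O)c2[nH]c(-c3cnn(Cc4ccccc4)c3)nc2n(CCC)c1=O`, 76 nM;
compound 3, `Cn1c(=O)c2[nH]c(-c3cnn(Cc4cccc(F)c4)c3)nc2n(C)c1=O`, 460 nM.

All three share one core and were tested in an assay on CHO cells for displacement of a labelled ligand from adenosine receptor A1 (Homo sapiens); on this read-out higher numbers stand for weaker inhibition and lower numbers for stronger inhibition. Compound 1 and compound 2 sit within the usual scatter of each other, so nothing separates them; compound 3 gives a clearly higher number, beyond that scatter. The next compound, compound 4, `CCCn1c(=O)c2nc(-c3cnn(Cc4cc(Cl)ccc4Cl)c3)[nH]c2n(CCC)c1=O`, differs from compound 1 in one place: 2,5-dichlorophenyl in place of 2-(trifluoromethyl)phenyl on a saturated chain carbon bound to an aromatic nitrogen. Among the compounds with values here, no measured pair shows this kind of change, so there is nothing to lean on. The step of a 1.1-fold lower number from compound 1 to compound 4 (0.04 log units; within the scatter) is expected to be small, in neither direction beyond the scatter. Compound 4 is therefore estimated at 40 nM, with a range from 15 nM to 120 nM.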

Compound 4, inhibition constant: 190 nM
The estimate for compound 4 lay 4.8-fold (0.68 log units) below the measured number, and the stated range ends below it.
By their numbers in this assay, from the lowest: compounds 1 and 2 (each within the scatter of the next); then compound 4; then compound 3.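

In this assay this position is not indifferent to the group it carries: 2,5-dichlorophenyl in place of 2-(trifluoromethyl)phenyl gives a 4.3-fold higher number from compound 1 to compound 4 (0.64 log units; beyond the scatter) and so moves the number beyond the scatter. Both groups hold one carbon-only aromatic ring with no hydrogen-bond donors or acceptors and no net charge, so those shared counts do not make them interchangeable here. Nothing available explains this step.

On these data alone, it remains open whether 2-chlorophenyl or 2-methoxyphenyl would stay close to compound 1 or follow compound 4. A single step also leaves open whether this change would have the same size on another core.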